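The source may report more compounds than this note shows. Statements on the series, on what has been measured and on what is new or still open speak of the compounds shown alone.

Measured so far in a functional assay on KB 3-1 cells (Homo sapiens) for cytotoxicity, read by MTT assay, with a stated time of 68 h; a lower number here means a stronger inhibitor, a higher number a weaker inhibitor:
Compound 1 `COC(=O)c1ccc(-c2cccc(NC(=O)C(Cl)Cl)c2)cc1` gives > 50000 nM.
Compound 2 `COc1ccc(-c2cc(NC(=O)C(Cl)Cl)cc(-c3ccc(OC)c(F)c3)c2)cc1F` gives 2940 nM.
Compound 3 `CCOc1ccc(-c2cc(NC(=O)C(Cl)Cl)cc(-c3ccc(OCC)cc3)c2)cc1` gives 24000 nM.

The value of compound 1 is only a limit of this assay and not a number, and compound 1 sits at the limit of > 50000 nM in this assay, at which 1 of the 3 values shown sits. Compounds 2 and 3 carry a different core and both give numbers, with compound 2 the lower of the two. Compound 4 `O=C(Nc1cccc(-c2ccccc2)c1)C(Cl)Cl` differs from compound 1 in one place: hydrogen in place of methoxycarbonyl on an aromatic carbon. Going by the values given here, no measured pair in this set shows what such a change does in this assay, so the step from compound 1 to compound 4 is expected to be small, with no direction beyond the scatter, and a step that the limit leaves unreadable from compound 1 to compound 4 is the estimated size. Compound 4 is expected to give about 60000 nM, within 15000 nM to 200000 nM, and quite possibly again only a limit.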

Compound 4, half-maximal inhibitory concentration: 46800 nM
For compound 4 the middle estimate is 1.3-fold (0.11 log units) above the measured one, within the range that was stated.
By their numbers in this assay, from the lowest: compound 2; then compounds 3 and 4 (each within the scatter of the next). At a limit, above all of these: compound 1.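

In this assay, hydrogen in place of methoxycarbonyl on this aromatic carbon gives an at least 1.0-fold lower number from compound 1 to compound 4 (0.02 log units; that floor lies within the scatter), so the pair shows no change beyond the scatter. Going by these compounds alone, compound 4 gives a number, which makes it the first compound with this substitution pattern that can be read at this position. The true size of the step stays unknown because compound 1 stands at a limit: the limit of > 50000 nM in this assay, at which 1 of the 4 values shown sits.

The compounds shown leave open how an amine or a carboxylic acid on this same carbon would compare with compound 4.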